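This account rests on a few compounds, and the source may have more. Where it says the series, first, only, none or still open, it means among the compounds named here.

Three compounds share one core, and each has been tested in a physicochemical assay for solubility, measured as kinetic solubility, at pH 2; a higher number here means a more soluble compound, a lower number a less soluble compound. Compound 1 `CC(C)C(Nc1nccs1)c1ccc(-c2ccc3cccc(F)c3c2)[nH]c1=O` gives 32900 nM in this assay. Compound 2 `CCn1ncc2c(F)cc(-c3ccc(C(CC)(CC)c4nnc(C)[nH]4)c(=O)[nH]3)cc21` gives 33900 nM in this assay. Compound 3 `CC(C)C(c1ccc(-c2ccc3cccc(F)c3c2)[nH]c1=O)N1CCNC1=O` gives 31600 nM in this assay. Among the measured compounds shown here, of these three numbers, the one for compound 3 is the lowest, but every gap between them is within the scatter, so the three compounds cannot be told apart on solubility. For the measured compounds named here, the only step measured at the same place is a 1.0-fold lower number from compound 1 to compound 3 (0.02 log units; within the scatter), a swap of groups on the saturated chain carbon that left the number unchanged.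

Compound 4 `CC(C)C(Cc1nnn[nH]1)c1ccc(-c2ccc3cccc(F)c3c2)[nH]c1=O` is not yet measured. It differs from compound 3 by (1H-tetrazol-5-yl)methyl in place of 2-oxoimidazolidin-1-yl on a saturated chain carbon bound to an aromatic carbon and a saturated chain carbon. Going by the values given here, no measured step tests this particular exchange, and the one step at this position was within the scatter, so no step beyond the scatter is expected in this assay. The estimated step is a 1.1-fold lower number from compound 3 to compound 4 (0.02 log units; within the scatter). Compound 4 is therefore expected to give about 30000 nM, within a range from 12000 nM to 75000 nM.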

Compound 4, solubility: 28000 nM
For compound 4 the middle estimate is 1.1-fold (0.03 log units) above the measured one, within the range that was stated.
By their numbers in this assay, from the lowest: compounds 4, 3, 1 and 2 (each within the scatter of the next).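

In this assay the exchange for (1H-tetrazol-5-yl)methyl gives a 1.1-fold lower number from compound 3 to compound 4 (0.05 log units; within the scatter) and a 1.2-fold lower number from compound 1 to compound 4 (0.07 log units; within the scatter) at this position, so both steps stay within the scatter. The change puts a five-membered aromatic ring with 4 hetero atoms where compound 3 has a five-membered non-aromatic ring with 2 hetero atoms, and the two compounds still cannot be told apart, which extends the earlier single step to a third group on this saturated chain carbon. No measurement shown bears on why these groups give numbers so close together.

The compounds shown leave open whether a group of another kind here, such as a carboxylic acid or a simple amine, would give a step beyond the scatter. A longer chain carrying the tetrazole ring remains a separate open question.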